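The compounds below may be only part of what the source reports. "The series", "measured", "known", "first", "only" and "open" are said of these compounds alone.

Compound 1, with the structure `COC1NN=C(C[S+]([O-])C(c2ccccc2)c2ccccc2)S1`, is one of three diphenylmethyl sulfoxides examined in an assay on HEK293 cells for inhibition of sodium-dependent dopamine transporter (Homo sapiens), read by scintillation counting, with stated times of 5 min and 1 min; a higher number here means a weaker inhibitor, a lower number a stronger inhibitor. In this assay compound 1 gives 108000 nM, which places it second highest of the three numbers. Compound 2, `[O-][S+](Cc1ccc(Cl)s1)C(c1ccccc1)c1ccccc1`, gives 12800 nM, and compound 3, `Cc1cc(O)nc(C[S+]([O-])C(c2ccccc2)c2ccccc2)n1`, gives 109000 nM. The step of an 8.4-fold lower number from compound 1 to compound 2 (0.93 log units; beyond the scatter) is beyond the scatter, whereas the step of a 1.0-fold higher number from compound 1 to compound 3 (0.00 log units; within the scatter) lies within it, so compound 1 and compound 3 cannot be ordered against each other.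

The unmeasured compound 4 has the structure `Cc1cnc(C[S+]([O-])C(c2ccccc2)c2ccccc2)nc1`. Relative to compound 1 the change is a group of 7 heavy atoms (5 carbon, 2 nitrogen; one six-membered aromatic ring with 2 hetero atoms) in place of a group of 7 heavy atoms (3 carbon, 2 nitrogen, 1 oxygen, 1 sulfur; one five-membered non-aromatic ring with 3 hetero atoms), on a saturated chain carbon bound to a sulfur. Among the compounds with values here, the nearest precedent is the step of a 1.0-fold higher number from compound 1 to compound 3 (0.00 log units; within the scatter), where a six-membered aromatic ring with two hetero atoms likewise replaced the five-membered non-aromatic ring and the number did not move. Within the data shown here, the only step that moved the number, an 8.4-fold lower number from compound 1 to compound 2 (0.93 log units; beyond the scatter), involved a different ring type and does not speak directly to compound 4. Because of the flat step a 1.0-fold higher number from compound 1 to compound 3 (0.00 log units; within the scatter) for compound 3, compound 4 is expected to show a 1.3-fold lower number from compound 1 to compound 4 (0.10 log units; within the scatter), a step that stays within the scatter. For compound 4 the estimated value is therefore 85000 nM, with a range from 25000 nM to 280000 nM.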

Compound 4, half-maximal inhibitory concentration: 156000 nM
Compound 4: middle estimate off by 1.8-fold (0.26 log units), on the low side; measured number inside the range.
By their numbers in this assay, from the lowest: compound 2; then compounds 1, 3 and 4 (each within the scatter of the next).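

With a 1.4-fold higher number from compound 1 to compound 4 (0.16 log units; within the scatter) and a 1.4-fold higher number from compound 3 to compound 4 (0.16 log units; within the scatter), this assay cannot separate 5-methylpyrimidin-2-yl from either the non-aromatic five-membered group of compound 1 or 4-hydroxy-6-methylpyrimidin-2-yl of compound 3, so on the saturated chain carbon bound to a sulfur, a group with no hydrogen-bond donor now stands level with the group of compound 1, which carries one. The a 12-fold higher number from compound 2 to compound 4 (1.09 log units; beyond the scatter) is beyond the scatter, which keeps 5-chlorothiophen-2-yl apart from all three nitrogen-bearing groups and makes compound 2, whose steps to compounds 1, 3 and 4 are all beyond the scatter, the strongest inhibitor of the four.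

The compounds shown cannot say whether the lower number of compound 2 goes with the chlorine or with the thiophene ring, since neither an unsubstituted thiophen-2-yl nor a 5-chloropyrimidin-2-yl stands among them. They also leave open what an amine or a carboxylic acid on this ring would do, and whether a longer chain between the sulfur and the ring would shift the number.

Nothing measured here accounts for any of these numbers.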